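This account rests on a few compounds, and the source may have more. Where it says the series, first, only, none or still open, it means among the compounds named here.

For the measured compounds named here, in a functional assay on A-375 cells (Homo sapiens) for inhibition, read by CCK-8 assay, with a stated time of 72 h, tested at 2 uM (on this read-out lower numbers stand for less inhibition of growth and higher numbers for more inhibition of growth at the one concentration tested), compound 1 (`Nc1ccccc1NC(=O)/C=C/c1ccc(CSc2ccc(C(F)(F)F)cn2)cc1`) gives 10.3% and compound 2 (`Nc1ccccc1NC(=O)/C=C/c1ccc(CSc2cccc3ccccc23)cc1`) gives 1.55% as the only numbers so far, both small and within the scatter of each other. Compound 3 (`Nc1ccccc1NC(=O)/C=C/c1ccc(CSCCc2ccccc2)cc1`) carries phenethyl in place of naphthalen-1-yl on a sulfur. Going by the values given here, the one measured change at this place is a number 8.8 percentage points lower from compound 1 to compound 2 (within the scatter) and it shows no shift beyond the scatter. Among the compounds with values here, no measured compound carries phenethyl there, so no step beyond the scatter is expected in this assay in either direction. The expected step stays small (a number 4.5 percentage points higher from compound 2 to compound 3 (within the scatter)). Compound 3 is estimated at 6% with an expected range of 0% to 16% for now.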

Compound 3, percent growth inhibition at one concentration: 41.9%
Compound 3: the middle estimate sits 35.9 percentage points below what was measured; the measured number lies above the stated range.
By their numbers in this assay, from the lowest: compounds 2 and 1 (each within the scatter of the next); then compound 3.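

In this assay, the group on this sulfur can move the read-out well beyond the scatter: phenethyl gives a number 40.4 percentage points higher from compound 2 to compound 3 (beyond the scatter) and a number 31.6 percentage points higher from compound 1 to compound 3 (beyond the scatter). Compound 1 and compound 2, with an aromatic ring directly on the sulfur, stay within the scatter of each other, whereas compound 3 places a chain before its single ring. Nothing at hand explains the step.

Going by these compounds, it remains open whether the chain or the change to one carbon ring accounts for the step. Phenyl, benzyl and 3-phenylpropyl on the sulfur would help separate these two changes.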